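The compounds below may be only part of what the source reports. "The series", "measured", "known", "first", "only" and "open" are said of these compounds alone.

Of the compounds shown here, two have been measured so far. Compound 1 `CC(=O)N1CCc2c(c(-c3ccc(Cl)cc3)nn2CC(O)CN2CCN(C(c3ccc(F)cc3)c3ccc(F)cc3)CC2)C1` and compound 2 `CC(=O)N1CCc2c(c(-c3ccc(Cl)c(C)c3)nn2CC(O)CN2CCC(n3c(=O)n(C)c4ccccc43)CC2)C1` share a core and differ in several places at once, so no single change can be tied to the gap between them. In an assay on isolated protein for inhibition of cathepsin S (Homo sapiens) (a lower number here means a stronger inhibitor, a higher number a weaker inhibitor), compound 1 gives 20 nM. In this assay compound 2 gives 500 nM, the higher of the two numbers and therefore the weaker inhibitor, and the gap to compound 1 is beyond the usual scatter of repeated measurements.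

Compound 3 `CC(=O)N1CCc2c(c(-c3ccc(Cl)c(C)c3)nn2CC(O)CN2CCC(n3c(=O)n(C(C)C)c4ccccc43)CC2)C1` has not yet been measured. It differs from compound 2 in one place only: isopropyl in place of methyl on an aromatic nitrogen. Going by the values given here, no measured pair shows what such a change does here, so the expectation rests on the single change itself and on the value of compound 2.

For compound 3 the expected step of a 1.3-fold lower number from compound 2 to compound 3 (0.10 log units; within the scatter) is small, with no clear direction beyond the scatter. In this assay compound 3 is therefore estimated at 400 nM, with a plausible range from 150 nM to 1200 nM, close to the number of compound 2 500 nM.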

Compound 3, half-maximal inhibitory concentration: 100 nM
Estimate against measurement, compound 3: 4.0-fold (0.60 log units) above; measured number outside the range, below it.
By their numbers in this assay, from the lowest: compound 1; then compound 3; then compound 2.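

In this assay, going by these compounds alone, putting isopropyl in place of methyl on the aromatic nitrogen gives a 5.0-fold lower number from compound 2 to compound 3 (0.70 log units; beyond the scatter), the first single change whose effect can be read on its own. It shows that this position responds to what it carries: a group of 3 carbon atoms in place of a group of 1, with no hydrogen-bond donor or acceptor and no net charge on either side, moves the number beyond the scatter, and towards a stronger inhibitor rather than a weaker one. Nothing measured here explains why isopropyl does better than methyl, so the gain stands as an observation only.

One pair cannot tell whether the gain follows the size of the group or the branched shape of isopropyl, a question that an ethyl group, a straight propyl chain or a cyclopropyl ring on the same nitrogen could help to settle. Also open, from the compounds shown here alone, is how this position would respond to a different kind of group, such as an amine or a carboxylic acid at the end of a longer chain.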